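This account rests on a few compounds, and the source may have more. Where it says the series, first, only, none or still open, it means among the compounds named here.

In a functional assay on Raji cells (Homo sapiens) for cytotoxicity, read by CCK-8 assay, with a stated time of 24 h (a higher number here means a weaker inhibitor, a lower number a stronger inhibitor), compound 1 `C=CC(=O)N1C(=O)CC(C)Sc2ccccc21` gives 837000 nM, and compound 2 `C=CC(=O)N1C(=O)CC(c2ccccc2Cl)Sc2ccccc21` gives 50400 nM, the lower of the two numbers. Among the compounds with values here, the only measured step is a 17-fold lower number from compound 1 to compound 2 (1.22 log units; beyond the scatter), a large one, with 2-chlorophenyl in place of methyl on a saturated ring carbon. Compound 3 `C=CC(=O)N1C(=O)CC(c2ccccc2C(F)(F)F)Sc2ccccc21` instead has trifluoromethyl in place of chloro on an aromatic carbon. The measured step bears on this change only indirectly, so no step beyond the scatter is expected in this assay. The estimated step is a 1.1-fold lower number from compound 2 to compound 3 (0.05 log units; within the scatter). Compound 3 is expected at 45000 nM, with an estimated range of 18000 nM to 110000 nM.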

Compound 3, half-maximal inhibitory concentration: 50300 nM
The estimate for compound 3 lay 1.1-fold (0.05 log units) below the measured number; low and high end bracket the measured number.
By their numbers in this assay, from the lowest: compounds 3 and 2 (each within the scatter of the next); then compound 1.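

In this assay, trifluoromethyl in place of chloro on this aromatic carbon, ortho to a large group, gives a 1.0-fold lower number from compound 2 to compound 3 (0.00 log units; within the scatter) and so stays within the scatter, even though the entering group has more heavy atoms. The earlier step concerned only the exchange of methyl for 2-chlorophenyl on a saturated ring carbon; this one shows that, for these two groups, the substituent on the aromatic ring can differ without a readable difference in this assay. No available evidence bears on this result. Still open, on these data alone, is how an amine, a carboxylic acid or a methoxy group would read at this carbon, and whether chloro or trifluoromethyl would read the same elsewhere on the ring.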